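Chloro for methyl on the core: cytotoxicity estimate

This account rests on a few compounds, and the source may have more. Where it says the series, first, only, none or still open, it means among the compounds named here.

Measured compounds:
compound 1 `COc1ccc2c(OCC[C@@H]3NC(=O)N(C)CCCC/C=C\[C@@H]4C[C@@]4(C(=O)NS(=O)(=O)C4(C)CC4)NC3=O)cc(-c3nc(C(C)C)cs3)nc2c1Cl`, 37400 nM
compound 2 `COc1ccc2c(OCC[C@@H]3NC(=O)N(C)CCCC/C=C\[C@@H]4C[C@@]4(C(=O)NS(=O)(=O)C4(C)CC4)NC3=O)cc(-n3ccc(C(C)C)n3)nc2c1C`, 25600 nM

In an ADME assay on cells (Homo sapiens) for activation (on this read-out lower numbers stand for higher toxicity in this test and higher numbers for lower toxicity in this test), compound 1 gives 37400 nM and compound 2 gives 25600 nM. Compound 2 holds the lower of the two numbers, yet the gap to compound 1 lies within the scatter, so the two read as alike. Compound 3 `COc1ccc2c(OCC[C@@H]3NC(=O)N(C)CCCC/C=C\[C@@H]4C[C@@]4(C(=O)NS(=O)(=O)C4(C)CC4)NC3=O)cc(-n3ccc(C(C)C)n3)nc2c1Cl` differs from compound 2 by chloro in place of methyl on an aromatic carbon. Among the measured compounds shown here, no measured pair isolates this change, so no size of step is known for it in this assay; beyond the scatter none is expected either way. Compound 3 is therefore estimated at 30000 nM, between 14000 nM and 65000 nM, an expected step of a 1.2-fold higher number from compound 2 to compound 3 (0.07 log units; within the scatter).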

Compound 3, half-maximal cytotoxic concentration: 31000 nM
Compound 3: middle estimate off by 1.0-fold (0.01 log units), on the low side, within the range that was stated.
By their numbers in this assay, from the lowest: compounds 2, 3 and 1 (each within the scatter of the next).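

In this assay, chloro in place of methyl on the aromatic carbon ortho to a methoxy group gives a 1.2-fold higher number from compound 2 to compound 3 (0.08 log units; within the scatter) and the two compounds read as alike, so this exchange at this position leaves no readable difference. With chloro held in place, 3-isopropyl-1H-pyrazol-1-yl in place of 4-isopropyl-1,3-thiazol-2-yl gives a 1.2-fold lower number from compound 1 to compound 3 (0.08 log units; within the scatter) and those two also read as alike. Nothing at hand offers an explanation for either result.

From the compounds shown here alone, whether an amine or a longer chain on this aromatic carbon would read the same in this assay remains open. Also open, going by these compounds, is whether the exchange of chloro for methyl behaves alike with 4-isopropyl-1,3-thiazol-2-yl on the core.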